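A few compounds are considered here, and "the series" means these few. Any claim that something is new, unique, unknown or untested is made for them only; others in the source may bear on it.

Measured compounds:
compound 1 `O=C(Nc1ccc(C(=O)N2CCCN(Cc3ccccc3)c3sccc32)cc1)c1ccccc1-c1ccccc1` gives 70 nM
compound 2 `CN1CCN(C(=O)CCCOc2cc(C(=O)N3CCCCc4sccc43)ccc2NC(=O)c2ccccc2-c2ccccc2)CC1` gives 1 nM
compound 3 `COc1cc(C(=O)N2CCCC(N(C)C)c3sccc32)ccc1NC(=O)c1ccccc1-c1ccccc1` gives 10 nM

The read-out throughout is an assay on adrenal medulla for inhibition of Vasopressin V2 receptor (Rattus norvegicus), read by radioligand binding; on this read-out lower numbers stand for stronger inhibition and higher numbers for weaker inhibition. Among these three, compound 2 stands lowest, with compound 3 nearest and compound 1 furthest, both gaps beyond the scatter, so compound 2 is the most potent of the three. Compound 4 `CN(C)C1CCN(C(=O)COc2cc(C(=O)N3CCCCc4sccc43)ccc2NC(=O)c2ccccc2-c2ccccc2)CC1` has the same atoms as compound 2 but joined differently: (4-(dimethylamino)piperidin-1-yl)carbonyl in place of 2-((4-methylpiperazin-1-yl)carbonyl)ethyl on a saturated chain carbon bound to an oxygen on an aromatic ring. Among the compounds with values here, no measured pair shows the same change, so the size of the step is open. A small step, within the scatter or barely beyond it, is expected, as the amide-bearing side chain is kept but shortened; the expected step from compound 2 to compound 4 in this assay is a 2.0-fold higher number from compound 2 to compound 4 (0.30 log units; within the scatter). Compound 4 is therefore estimated at 2 nM, within a range of 0.5 nM to 8 nM.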

Compound 4, half-maximal inhibitory concentration: 4 nM
Beside the measured number, compound 4's estimate is 2.0-fold (0.30 log units) below it; measured number inside the range.
By their numbers in this assay, from the lowest: compound 2; then compound 4; then compound 3; then compound 1.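

In this assay, (4-(dimethylamino)piperidin-1-yl)carbonyl in place of 2-((4-methylpiperazin-1-yl)carbonyl)ethyl on a saturated chain carbon bound to an oxygen on an aromatic ring gives a 4.0-fold higher number from compound 2 to compound 4 (0.60 log units; beyond the scatter), a modest step. Within the data shown here, this is the first one-place comparison here, and it shows that this position registers a rearrangement of the same atoms. Nothing available explains the step.

On these data alone, the change alters chain length and amine ring together, so their separate contributions remain open. Also open, as far as these compounds go, is how a morpholine amide or a carboxylic acid would fare at this position.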